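The source may hold more compounds than are shown below. What is called first, only, known or untested is meant among the compounds shown, and "the series" means these compounds.

Working notes on the series. The shared core carries a sulfonamide nitrogen whose substituent varies across the set. Compound 1 `CCCNC(=S)NS(=O)(=O)c1ccc(-n2nc(C(=O)O)cc2C)cc1` bears the shortest group there. In a functional assay on the whole organism (blood, strain albino) with Mus musculus as the target, with stated times of 6 days and 4 h, at a dose of 0.4 mmol/kg by the oral route (on this read-out higher numbers stand for more inhibition at the one dose given (going by the name of the read-out) and lower numbers for less inhibition), compound 1 reads < 1%, which is a limit of the assay and not a number. Compound 2 `CCCCNC(=O)NS(=O)(=O)c1ccc(-n2nc(C(=O)O)cc2C)cc1` gives 2% in this assay, the only number shown for the whole set. Among the compounds with values here, the single measured step, a number at least 1 percentage points higher from compound 1 to compound 2 (that floor lies within the scatter), changes the chain length and exchanges sulfur for oxygen in one move, so it cannot separate the two effects. Compound 3 `CCCCNC(=S)NS(=O)(=O)c1ccc(-n2nc(C(=O)O)cc2C)cc1` is not yet measured; relative to compound 2 the change is a group of 7 heavy atoms (5 carbon, 1 nitrogen, 1 sulfur; no ring) in place of a group of 7 heavy atoms (5 carbon, 1 nitrogen, 1 oxygen; no ring), on a sulfonamide nitrogen. The measured step bears on this change only in part, and in the reverse sense for the sulfur and oxygen exchange, while the longer chain of compound 2 is kept. That step was within scatter, and because its lower value sat at a limit (the limit of < 1% in this assay, at which 1 of the 2 values shown sits), no direction beyond the scatter is expected here. The expected change in this assay is no change at the digits printed from compound 2 to compound 3 (within the scatter). Compound 3 is therefore estimated at 2%, within 0% to 10%, with a real chance that only a limit is reported.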

Compound 3, a percentage reported as inhibition, in the whole organism at one dose (the size of the read-out at that dose, not a potency): < 1%
Compound 3: no number, only a limit; the forecaster's own chance of this, stated with the estimate: 40%; middle value at least 1 percentage points from the limit.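

Within the data shown here, with the butyl chain held fixed, the exchange of butylcarbamoyl for its sulfur counterpart on a sulfonamide nitrogen gives a number at least 1 percentage points lower from compound 2 to compound 3 (that floor lies within the scatter) in this assay, the first step that isolates the oxygen and sulfur exchange from any change in the chain. The step from compound 1 to compound 3, which isolates methyl in place of hydrogen on a saturated chain carbon, cannot be read, because both of its ends are limits: the limit of < 1% in this assay, at which 2 of the 3 values shown sit.

So neither the oxygen and sulfur exchange nor the chain change is shown here to move this read-out beyond the scatter at the one dose given.

The compounds shown leave open whether a propylcarbamoyl group, the oxygen partner of the group in compound 1, would complete the set of chain and exchange pairs. They also leave open whether a substantially different group on a sulfonamide nitrogen, such as hexylcarbamoyl or cyclohexylcarbamoyl, would give a value clear of the limit and of the scatter in this assay.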